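Swapping Chloro for Fluoro on the Benzyl Ring

A few compounds are considered here, and "the series" means these few. Any claim that something is new, unique, unknown or untested is made for them only; others in the source may bear on it.

Two measured compounds share one core. Compound 1 `Nc1cccc(/C=C2\SC(=O)N(Cc3cccc(Cl)c3)C2=O)c1` gives 211000 nM in a functional assay on L1210 cells (Mus musculus) for cytotoxicity, read by cell counting, with a stated time of 2 days (a higher number here means a weaker inhibitor, a lower number a stronger inhibitor), and compound 2 `Nc1ccc(/C=C2\SC(=O)N(Cc3cccc(Cl)c3)C2=O)cc1` gives 4700 nM. Going by the values given here, the single measured step, a 45-fold lower number from compound 1 to compound 2 (1.65 log units; beyond the scatter), concerns where the amino group sits on its ring. Among the compounds with values here, compound 2 therefore holds the lower of the two numbers, its only neighbour being compound 1 at a far higher number. Compound 3 `Nc1ccc(/C=C2\SC(=O)N(Cc3cccc(F)c3)C2=O)cc1` differs from compound 2 by fluoro in place of chloro on an aromatic carbon. Within the data shown here, no measured step touches this ring: the one step available, from compound 1 to compound 2, moved an amino group on the other aromatic ring and was large, so it says nothing about trading one halogen for another here. Without any step bearing on the change, the swap is expected to give a step of a 1.3-fold higher number from compound 2 to compound 3 (0.11 log units; within the scatter) in this assay, a shift not beyond the scatter. Compound 3 is thus estimated at 6000 nM, with a range of 2000 nM to 18000 nM.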

Compound 3, half-maximal inhibitory concentration: 100000 nM
Compound 3: middle estimate off by 17-fold (1.22 log units), on the low side; the whole stated range lies below it.
By their numbers in this assay, from the lowest: compound 2; then compound 3; then compound 1.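

In this assay the 3-chlorophenyl group proves not to be interchangeable with 3-fluorophenyl: exchanging one halogen for the other gives a 21-fold higher number from compound 2 to compound 3 (1.33 log units; beyond the scatter) and so leaves the read-out clearly changed. Going by these compounds alone, this is the first measured sign that the benzyl ring, untouched by the earlier step, also bears on the read-out, since the change of a single heavy atom on an aromatic carbon here is classed as large, just as a 45-fold lower number from compound 1 to compound 2 (1.65 log units; beyond the scatter) is on the other aromatic ring. Nothing at hand gives a reason for the size of this halogen step.

The compounds shown leave open how other groups on this same aromatic carbon would read, such as bromo, methyl or methoxy, and how the benzyl ring with only hydrogen there would compare with the chloro and fluoro compounds. They also leave open whether the exchange of chloro for fluoro would give a step of similar size on the core of compound 1, where the amino group stands on the other ring position, or whether the step belongs to the 4-aminophenyl series alone.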